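This account rests on a few compounds, and the source may have more. Where it says the series, first, only, none or still open, it means among the compounds named here.

Compound 1 `CCCc1cc(N)c2cc(NC(=O)/C=C/c3ccc(F)cc3)ccc2n1`: 130 nM
Compound 2 `CCCc1cc(N)c2cc(NC(=O)/C=C/c3ccc(C(C)(C)C)cc3)ccc2n1`: 22 nM
Compound 3 `CCCc1cc(N)c2cc(NC(=O)/C=C/c3ccc(I)cc3)ccc2n1`: 2.3 nM

In an assay on isolated protein for displacement of a labelled ligand from melanin-concentrating hormone receptor 1 (Homo sapiens) (a lower number here means a stronger inhibitor, a higher number a weaker inhibitor), compound 3 gives the lowest of the three numbers; compound 2 comes nearest to it, and compound 1 lies furthest away. Compound 4 `CCCCc1ccc(/C=C/C(=O)Nc2ccc3nc(CCC)cc(N)c3c2)cc1` differs from compound 3 in one place: butyl in place of iodo on an aromatic carbon. Among the compounds with values here, two measured steps bear on this exchange. The step of a 57-fold lower number from compound 1 to compound 3 (1.75 log units; beyond the scatter) and the step of a 9.6-fold lower number from compound 2 to compound 3 (0.98 log units; beyond the scatter) both show iodo giving a lower number than either fluoro or tert-butyl, with tert-butyl the closer of the two. Since butyl, like tert-butyl, is a carbon group rather than a halogen, a modest step upward in this assay is expected, a 5.2-fold higher number from compound 3 to compound 4 (0.72 log units; beyond the scatter). Compound 4 is therefore estimated at 12 nM, within 3 nM to 50 nM.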

Compound 4, half-maximal inhibitory concentration: 45 nM
Estimate against measurement, compound 4: 3.8-fold (0.57 log units) below, and the stated range covers the measured number.
By their numbers in this assay, from the lowest: compound 3; then compound 2; then compound 4; then compound 1.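

In this assay, the exchange of iodo for butyl costs much of the strength seen at this position, with a 20-fold higher number from compound 3 to compound 4 (1.29 log units; beyond the scatter), while butyl still improves on fluoro, with a 2.9-fold lower number from compound 1 to compound 4 (0.46 log units; beyond the scatter). The two carbon groups lie closer together, with a 2.0-fold higher number from compound 2 to compound 4 (0.31 log units; beyond the scatter), so tert-butyl gives the lower number and neither carbon group reaches iodo. Nothing available explains why iodo stands apart from these groups. On these data alone, whether bromo or chloro would come close to iodo remains open. So does the effect of a longer chain such as hexyl, or of an amine, at this position.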